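Two Trimethoxyphenyl Isomers in a Cytotoxicity Test

The source may hold more compounds than are shown below. What is called first, only, known or untested is meant among the compounds shown, and "the series" means these compounds.

compound 1 `O=C(N/N=C/c1cccc(Cl)c1Cl)Nc1cc2c(Nc3ccc(F)c(Cl)c3)ncnc2cc1O[C@H]1CCOC1` gives 25000 nM
compound 2 `COc1ccc(/C=N/NC(=O)Nc2cc3c(Nc4ccc(F)c(Cl)c4)ncnc3cc2O[C@H]2CCOC2)c(OC)c1OC` gives 25200 nM

In a functional assay on A549 cells (Homo sapiens) for cytotoxicity, read by MTT assay, with a stated time of 72 h (on this read-out higher numbers stand for weaker inhibition and lower numbers for stronger inhibition), compound 2 gives 25200 nM and sits level with compound 1, within the scatter. Compound 3 `COc1cc(/C=N/NC(=O)Nc2cc3c(Nc4ccc(F)c(Cl)c4)ncnc3cc2O[C@H]2CCOC2)cc(OC)c1OC` differs from compound 2 in one place, and the change 3,4,5-trimethoxyphenyl in place of 2,3,4-trimethoxyphenyl on a carbon with a double bond to nitrogen puts 3,4,5-trimethoxyphenyl in place of 2,3,4-trimethoxyphenyl on a carbon with a double bond to nitrogen. The atoms stay the same and are only joined differently.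

For the measured compounds named here, the one measured step that bears on this is a 1.0-fold higher number from compound 1 to compound 2 (0.00 log units; within the scatter) with 2,3,4-trimethoxyphenyl in place of 2,3-dichlorophenyl on that same kind of carbon. That exchange of quite different groups stayed within the scatter, so no step beyond the scatter is expected in this assay for this rearrangement. A single step is thin evidence, however, so the range is kept wide. The estimated step is a 1.1-fold lower number from compound 2 to compound 3 (0.02 log units; within the scatter) and lies within the scatter. For compound 3 the expected value is 24000 nM within a range of 10000 nM to 50000 nM on present evidence.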

Compound 3, half-maximal inhibitory concentration: 26400 nM
Compound 3: middle estimate off by 1.1-fold (0.04 log units), on the low side, within the range that was stated.
By their numbers in this assay, from the lowest: compounds 1, 2 and 3 (each within the scatter of the next).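

In this assay, the swap of 3,4,5-trimethoxyphenyl for 2,3,4-trimethoxyphenyl on a carbon with a double bond to nitrogen gives a 1.0-fold higher number from compound 2 to compound 3 (0.02 log units; within the scatter). The atoms are the same and only their arrangement differs, so rearranging this group makes no difference that this read-out can detect. The exchange of 2,3-dichlorophenyl for 3,4,5-trimethoxyphenyl at the same place gives a 1.1-fold higher number from compound 1 to compound 3 (0.02 log units; within the scatter), so all three groups now shown, chlorine-bearing or methoxy-bearing, sit level with one another, and nothing measured here explains why this place responds so little to these changes.

As far as these compounds go, all three groups are substituted phenyl rings, so it remains open whether the same flat picture would hold for a group of another kind at this place, such as an amine, a carboxylic acid or a longer chain. Since only this one place varies among the compounds shown, it also remains open how much the values would move if a change were made elsewhere on the shared core.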